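Two Measured Esters and One Expected Value

The source may hold more compounds than are shown below. What is called first, only, known or untested is meant among the compounds shown, and "the series" means these compounds.

Measured in a functional assay on the whole organism (strain Kunming) with Mus musculus as the target, with a stated time of 0.5 h (on this read-out lower numbers stand for an effect already at smaller amounts and higher numbers for an effect only at larger amounts of compound), so far:
Compound 1 (`COc1cc(OC)c(OC)cc1/C=C/COC(=O)/C=C/c1ccc(OC)c(OC)c1`): 418 umol/kg
Compound 2 (`COc1cc(OC)c(OC)cc1/C=C/COC(=O)/C=C/c1cc(OC)c(OC)c(OC)c1OC`): 327 umol/kg

Of the compounds shown here, two have numbers so far. Compound 2 stands at 327 umol/kg in this assay and lies within the usual scatter of compound 1 at 418 umol/kg on the same read-out, so the two cannot be told apart. Compound 3 (`COc1cc(OC)c(OC)cc1/C=C/COC(=O)/C=C/c1cc(OC)c(OC)c(OC)c1`) has not yet been measured. It departs from compound 2 by a single change, hydrogen in place of methoxy on an aromatic carbon, at a place ortho to a large group.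

Going by the values given here, no measured pair that differs in one place is available, so the size of such a change has not been seen directly. Among the compounds with values here, the only guide is the closeness of the two values in hand, and no step beyond the scatter is expected in this assay for this change, in either direction. The expected step is a 1.1-fold higher number from compound 2 to compound 3 (0.03 log units; within the scatter) and it stays within the scatter. Compound 3 is expected to read 350 umol/kg within a range from 170 umol/kg to 720 umol/kg on this estimate.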

Compound 3, dose for half-maximal effect: 459 umol/kg
Compound 3: the middle estimate sits 1.3-fold (0.12 log units) below what was measured, within the range that was stated.
By their numbers in this assay, from the lowest: compounds 2, 1 and 3 (each within the scatter of the next).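

Hydrogen in place of methoxy on an aromatic carbon, ortho to a large group, can now be read directly: in this assay it gives a 1.4-fold higher number from compound 2 to compound 3 (0.15 log units; within the scatter) and so shows that this methoxy can be exchanged without a step beyond the scatter on this read-out. Methoxy in place of hydrogen on an aromatic carbon, the other single change now available, gives a 1.1-fold higher number from compound 1 to compound 3 (0.04 log units; within the scatter) and likewise does not separate the two compounds it connects, so neither change tells the compounds apart here. Nothing at hand offers an explanation for either step.

The compounds shown leave open whether this position responds to anything other than methoxy and hydrogen, such as an amine, a hydroxyl or a fluorine, and whether any group placed there would give a step beyond the scatter. They also leave open whether these changes would read the same way if an amide took the place of the ester or if ethoxy groups took the place of the methoxy groups on the other ring.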